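Cyclopropyl in place of hydrogen on an aromatic nitrogen

The compounds below may be only part of what the source reports. "The series", "measured", "known", "first", "only" and "open" are said of these compounds alone.

Measured in an assay on isolated protein for inhibition of Discoidin domain-containing receptor 2 (Homo sapiens), read by ELISA, with a stated time of 60 min; on this read-out higher numbers stand for weaker inhibition and lower numbers for stronger inhibition:
- compound 1 `Cc1ccc(C(=O)Nc2cccc(CN3CCN(C)CC3)c2)cc1-c1ccc2cn[nH]c2c1`: 75.9 nM
- compound 2 `Cc1ccc(C(=O)Nc2cccc(C(F)(F)F)c2)cc1-c1ccc2c(-c3ccc(C(=O)N4CCN(C)CC4)cc3)n[nH]c2c1`: 6.5 nM
- compound 3 `Cc1ccc(C(=O)Nc2cccc(C(F)(F)F)c2)cc1-c1ccc2c(-c3cn[nH]c3)n[nH]c2c1`: 55.6 nM

Compound 3 stands second highest of the three numbers. Its nearest neighbour is compound 1, whose value lies within the scatter of that of compound 3, so no order between these two can be claimed. Compound 2 is the furthest away, with the lower number, and that gap lies beyond the scatter.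

Compound 4 `Cc1ccc(C(=O)Nc2cccc(C(F)(F)F)c2)cc1-c1ccc2c(-c3cnn(C4CC4)c3)n[nH]c2c1` has not yet been measured in this assay. Set against compound 3, it differs in one place: cyclopropyl in place of hydrogen on an aromatic nitrogen. Among the compounds with values here, no step between measured compounds bears directly on this change, so the expectation rests on the spread of the three numbers and the size of the change alone. The group that enters is small, and the spread among compounds 1, 2 and 3 shows that larger additions at the same end of the molecule can move the number, as seen in compound 2. The step from compound 3 to compound 4 is expected to be small, a 1.9-fold lower number from compound 3 to compound 4 (0.27 log units; within the scatter), pointing if anywhere toward lower numbers and not clearly beyond the scatter. Compound 4 is therefore estimated at 30 nM in this assay, with a range from 10 nM to 90 nM.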

Compound 4, half-maximal inhibitory concentration: 3.2 nM
Beside the measured number, compound 4's estimate is 9.4-fold (0.97 log units) above it, outside the stated range (below it).
By their numbers in this assay, from the lowest: compound 4; then compound 2; then compounds 3 and 1 (each within the scatter of the next).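

In this assay, the series now has its first step that can be read at a single place: cyclopropyl in place of hydrogen on an aromatic nitrogen gives a 17-fold lower number from compound 3 to compound 4 (1.24 log units; beyond the scatter). The earlier compounds shown here offered no such step, and this one shows that the hydrogen on this nitrogen is not needed for inhibition in this assay, and that a group of only 3 heavy atoms, with no hydrogen-bond donors or acceptors, can move the number well beyond the scatter. Nothing available here accounts for the size of the step.

From the compounds shown here alone, the finding rests on one pair, so it remains open whether the step belongs to cyclopropyl in particular or would also follow from a methyl, an isopropyl, a cyclobutyl or a longer chain such as n-butyl on the same nitrogen. Also open, going by these compounds, is how this nitrogen would respond to a chain ending in an amine or a carboxylic acid, and whether the step would carry over to a compound with the amide end of compound 1.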